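The source may report more compounds than this note shows. Statements on the series, on what has been measured and on what is new or still open speak of the compounds shown alone.

Compound 1 `COc1cc2ncnc(Nc3ccc(F)c(Cl)c3)c2cc1OCCCCC(=O)Nc1ccc(S(N)(=O)=O)cc1` — in a functional assay on NCI-H1975 cells (Homo sapiens) for antiproliferative activity, read by MTT assay, with a stated time of 72 h (a higher number here means a weaker inhibitor, a lower number a stronger inhibitor), compound 1 gives 35600 nM.
Compound 2 `COc1cc2ncnc(Nc3cccc(Cl)c3)c2cc1OCCCCC(=O)Nc1ccc(S(N)(=O)=O)cc1` — in this assay compound 2 gives 33200 nM.
Compound 3 `COc1cc2ncnc(Nc3cccc(F)c3)c2cc1OCCCCC(=O)Nc1ccc(S(N)(=O)=O)cc1` — in this assay compound 3 gives only a limit of the assay, > 40000 nM.

All three compounds share the same core and differ only in the substituents on the aniline ring. Compound 3 stands at the assay limit, so its true number is not known beyond that floor (the limit of > 40000 nM in this assay, at which 1 of the 3 values shown sits). The measured steps that touch this ring are small: a 1.1-fold lower number from compound 1 to compound 2 (0.03 log units; within the scatter), an at least 1.1-fold higher number from compound 1 to compound 3 (0.05 log units; that floor lies within the scatter) and an at least 1.2-fold higher number from compound 2 to compound 3 (0.08 log units; that floor lies within the scatter). None of them moves the number beyond the usual scatter, and all three compounds are weak inhibitors.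

Compound 4 `COc1cc2ncnc(Nc3cccc(C)c3)c2cc1OCCCCC(=O)Nc1ccc(S(N)(=O)=O)cc1` is the next compound, unmeasured so far. The change is methyl in place of fluoro on an aromatic carbon. Given that swapping chloro, fluoro or hydrogen at this ring produced no step beyond the scatter, exchanging fluoro for methyl is expected to leave the number close to where compound 3 sits. The expected step of a number no higher from compound 3 to compound 4 (the limit leaves the size open) is within the scatter. Compound 4 is therefore estimated at about 40000 nM in this assay, with a range from 22000 nM to 80000 nM, and it may well again be reported only as a limit.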

Compound 4, half-maximal inhibitory concentration: 32100 nM
Estimate against measurement, compound 4: 1.2-fold (0.10 log units) above, and the stated range covers the measured number.
By their numbers in this assay, from the lowest: compounds 4, 2 and 1 (each within the scatter of the next). At a limit, above all of these: compound 3.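

Methyl is a carbon group, unlike the halogens at this place on the ring, yet in this assay the comparison with chloro gives a 1.0-fold lower number from compound 2 to compound 4 (0.01 log units; within the scatter), and the comparison with the 3-chloro-4-fluorophenyl group gives a 1.1-fold lower number from compound 1 to compound 4 (0.04 log units; within the scatter). The swap from fluoro to methyl gives an at least 1.2-fold lower number from compound 3 to compound 4 (0.09 log units; that floor lies within the scatter), and compound 4 has a measured number where compound 3 has only a limit. The true size of that step therefore stays unknown: the limit of > 40000 nM in this assay, at which 1 of the 4 values shown sits.

On these data alone, all steps between the measured compounds lie within the scatter, so the ring's tolerance for other groups remains untested by these compounds. As far as these compounds go, whether an amine, a carboxylic acid or a longer chain in place of the methyl would move the number beyond the scatter stays open.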